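Pyrrolidine triol series against alpha-mannosidase 2

The source may hold more compounds than are shown below. What is called first, only, known or untested is meant among the compounds shown, and "the series" means these compounds.

Measured compounds:
- compound 1, `C[C@H](O)NC[C@H]1NC[C@H](O)[C@@H]1O`: 683000 nM
- compound 2, `OCC(O)[C@H]1NC[C@H](O)[C@@H]1O`: 229000 nM
- compound 3, `C[C@@H](O)NC[C@H]1NC[C@H](O)[C@@H]1O`: 450000 nM

All three numbers come from an assay on isolated protein for inhibition of alpha-mannosidase 2 (Homo sapiens); on this read-out higher numbers stand for weaker inhibition and lower numbers for stronger inhibition. Compound 3 stands second highest of the three; its nearest neighbour is compound 1 and its furthest is compound 2, and both gaps lie within the scatter, so no order among the three can be claimed.

The next compound is compound 4, `NC[C@H]1NC[C@H](O)[C@@H]1O`. It differs from compound 3 by hydrogen in place of 1-hydroxyethyl on an amine nitrogen.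

Within the data shown here, the only measured step that bears on this position is the one from compound 1 to compound 3, a 1.5-fold lower number from compound 1 to compound 3 (0.18 log units; within the scatter); it rests on the fact that compounds 1 and 3 differ only in the configuration as drawn and shows that the configuration of the 1-hydroxyethyl group makes no difference beyond the scatter. Nothing measured shows what removing that group altogether does. Given that, the expectation for compound 4 in this assay is a step of a 1.1-fold lower number from compound 3 to compound 4 (0.05 log units; within the scatter), that is, no change beyond the scatter, with a wide allowance in either direction.

Compound 4 is therefore expected to give 400000 nM, in the range 130000 nM to 1200000 nM.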

Compound 4, inhibition constant: 1310000 nM
Estimate against measurement, compound 4: 3.3-fold (0.52 log units) below; the whole stated range lies below it.
By their numbers in this assay, from the lowest: compounds 2, 3, 1 and 4 (each within the scatter of the next, the first and the last beyond it).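

In this assay, among these compounds, hydrogen in place of 1-hydroxyethyl on the amine nitrogen is the first change at this position that registers beyond the scatter: a 2.9-fold higher number from compound 3 to compound 4 (0.46 log units; beyond the scatter). Read from the other configuration, the same replacement gives a 1.9-fold higher number from compound 1 to compound 4 (0.28 log units; within the scatter), which stays within the scatter, so the modest loss is established only from compound 3 and is not a firm result for both forms. The two steps share their end point and can be read as one replacement made from a single stereochemical pair, so the 1-hydroxyethyl group on this nitrogen has some small bearing on the number, while its drawn configuration shows none beyond the scatter: the fact that compounds 1 and 3 differ only in the configuration as drawn.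

From the compounds shown here alone, an ethyl group on the same nitrogen would separate the contribution of the two carbons from that of the hydroxyl, and which of them carries the step remains open. Also open, going by these compounds, is whether a longer chain or a benzyl group at this place gives a number lower than that of compound 3, 450000 nM.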